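Replacing a linked pyridine with a directly attached one

The compounds below may be only part of what the source reports. "The series", "measured", "known", "first", "only" and "open" are said of these compounds alone.

Measured so far:
Compound 1 `CC(C)=CCC1=C(OCc2cn(-c3ccnc4cc(Cl)ccc34)nn2)C(=O)c2ccccc2C1=O`: 1940000 nM
Compound 2 `CC(C)=CCC1=C(OCc2cn(C3CCNCC3)nn2)C(=O)c2ccccc2C1=O`: 570000 nM
Compound 3 `CC(C)=CCC1=C(OCc2cn(Cc3ccccn3)nn2)C(=O)c2ccccc2C1=O`: 658000 nM

All three share one core and differ only in the group on an aromatic nitrogen. In an ADME assay on HepG2 cells (Homo sapiens) for cytotoxicity, read by MTT assay, with a stated time of 24 h (a higher number here means that more compound is tolerated, a lower number that less compound is tolerated), compound 3 stands second highest; its number and that of compound 2 lie within the scatter of each other, while compound 1 gives a clearly higher number, as the step of a 2.9-fold lower number from compound 1 to compound 3 (0.47 log units; beyond the scatter) shows.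

Compound 4 `CC(C)=CCC1=C(OCc2cn(-c3cccnc3)nn2)C(=O)c2ccccc2C1=O` has not been measured. The change pyridin-3-yl in place of (pyridin-2-yl)methyl on an aromatic nitrogen brings a ring onto the aromatic nitrogen without the methylene link. Among the compounds with values here, the measured steps bear on it only loosely: a 3.4-fold lower number from compound 1 to compound 2 (0.53 log units; beyond the scatter) and a 2.9-fold lower number from compound 1 to compound 3 (0.47 log units; beyond the scatter) both show that the one compound whose ring sits directly on the nitrogen, compound 1, gives a higher number than those with a linked or saturated group, while a 1.2-fold higher number from compound 2 to compound 3 (0.06 log units; within the scatter) shows no difference beyond the scatter between the latter two. A modest rise is therefore expected, of about a 1.5-fold higher number from compound 3 to compound 4 (0.18 log units; within the scatter). Compound 4 is estimated at 1000000 nM, within a range of 500000 nM to 2000000 nM.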

Compound 4, half-maximal cytotoxic concentration: 1030000 nM
Compound 4: middle estimate off by 1.0-fold (0.01 log units), on the low side; the measured number falls inside the stated range.
By their numbers in this assay, from the lowest: compounds 2, 3, 4 and 1 (each within the scatter of the next, the first and the last beyond it).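

In this assay, taking away the methylene link and setting the ring directly on the aromatic nitrogen as pyridin-3-yl gives no change beyond the scatter (a 1.6-fold higher number from compound 3 to compound 4 (0.19 log units; within the scatter)). Compound 4 also lies within the scatter of the two other compounds (a 1.8-fold higher number from compound 2 to compound 4 (0.26 log units; within the scatter); a 1.9-fold lower number from compound 1 to compound 4 (0.27 log units; within the scatter)), although compound 1 and compound 2 are separated beyond it. A directly attached ring therefore does not by itself set a compound apart from the linked or saturated groups, and this change alters both the link and the point of attachment on the pyridine, so their shares cannot be told apart.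

No measurement shown here explains these numbers. Going by these compounds, it remains open what a directly attached pyridin-2-yl, a longer chain such as pyridin-2-ylethyl, or a carboxylic acid on the ring would give.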